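Replacing Pyrimidin-4-yl with a Larger Two-Ring Group

The compounds below may be only part of what the source reports. "The series", "measured", "known", "first", "only" and "open" are said of these compounds alone.

In a functional assay on K562 cells (Homo sapiens) for inhibition, read by trypan blue exclusion, with a stated time of 72 h (on this read-out lower numbers stand for stronger inhibition and higher numbers for weaker inhibition), compound 3 (`Cn1c(=O)c(S(=O)(=O)c2ccc(F)cc2F)cc2cnc(Nc3ccncn3)nc21`) gives 30000 nM, level with compound 2 (`Cn1c(=O)c(S(=O)(=O)Cc2ccc(F)cc2)cc2cnc(Nc3ccc4[nH]ccc4c3)nc21`) at 30000 nM. Together they hold the highest number of the three, and compound 1 (`Cn1c(=O)c(S(=O)(=O)c2ccc(C(=O)O)cc2)cc2cnc(Nc3ccc4[nH]ccc4c3)nc21`) gives 5000 nM. Compound 4 (`Cn1c(=O)c(S(=O)(=O)c2ccc(F)cc2F)cc2cnc(Nc3cnc4[nH]ccc4c3)nc21`) differs from compound 3 by a group of 9 heavy atoms (7 carbon, 2 nitrogen; one five-membered aromatic ring with 1 hetero atom, one six-membered aromatic ring with 1 hetero atom) in place of a group of 6 heavy atoms (4 carbon, 2 nitrogen; one six-membered aromatic ring with 2 hetero atoms), on a nitrogen on an aromatic ring. Among the measured compounds shown here, no measured step changes the group at this place. The only one, a 6.0-fold higher number from compound 1 to compound 2 (0.78 log units; beyond the scatter), is a change on a sulfonyl sulfur, so it serves only as a rough guide to size. With little certainty, the expected step of similar size is therefore a 5.0-fold lower number from compound 3 to compound 4 (0.70 log units; beyond the scatter). For compound 4, the estimated value is 6000 nM, with an expected range of 800 nM to 30000 nM.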

Compound 4, half-maximal inhibitory concentration: 750 nM
For compound 4 the middle estimate is 8.0-fold (0.90 log units) above the measured one; the whole stated range lies above it.
By their numbers in this assay, from the lowest: compound 4; then compound 1; then compounds 2 and 3 (each within the scatter of the next).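

In this assay, the two-ring group in place of pyrimidin-4-yl gives a 40-fold lower number from compound 3 to compound 4 (1.60 log units; beyond the scatter), so this place, on a nitrogen on an aromatic ring, can shift the number strongly. The step changes several things together: a second ring enters, the group grows, and it gains a hydrogen-bond donor that pyrimidin-4-yl lacks, so these cannot be told apart. No evidence at hand bears on why the number falls. From the compounds shown here alone, whether a plain phenyl on this nitrogen would give a similar number remains open. So does whether the step would carry over with 4-carboxyphenyl on the sulfonyl sulfur.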